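A few compounds are considered here, and "the series" means these few. Any claim that something is new, unique, unknown or untested is made for them only; others in the source may bear on it.

Compound 1, `Cc1cn([C@H]2C[C@H](N)[C@@H](CO)O2)c(=O)[nH]c1=O`: 100 uM
Compound 2, `NC1CC(n2cc(I)c(=O)[nH]c2=O)OC1CO`: > 100 uM

In a functional assay on D-38 cells (Homo sapiens) for cytotoxicity (a lower number here means that less compound is needed, a higher number that more compound is needed for the effect), compound 1 gives 100 uM. Compound 2 is known only by a limit of this assay, > 100 uM, and stands at the limit of > 100 uM in this assay, at which 1 of the 2 values shown sits. Compound 3, `NC1CC(n2cc(Br)c(=O)[nH]c2=O)OC1CO`, differs from compound 2 by bromo in place of iodo on an aromatic carbon. Among the measured compounds shown here, no measured pair shows a step of this kind, so the account expects no change beyond the usual scatter, in either direction. Compound 3 is therefore expected near 100 uM, within 50 uM to 300 uM. This estimate is expected to mean a number no higher from compound 2 to compound 3 (the limit leaves the size open).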

Compound 3, concentration for half-maximal effect: > 100 uM
Compound 3 ended at the assay's limit (the forecaster's own chance of this, stated with the estimate: 60%); the middle value sits exactly at the limit.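

Compound 2 and compound 3 both stand at a limit of this assay, so no step between them can be read: the limit of > 100 uM in this assay, at which 2 of the 3 values shown sit.

The compounds shown leave open whether bromo in place of iodo on an aromatic carbon changes the value at all.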